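Thiazole for furan on a shared core

The source may report more compounds than this note shows. Statements on the series, on what has been measured and on what is new or still open speak of the compounds shown alone.

Compound 1, `Cc1ccccc1C(c1ccccc1)N1CCN(c2ncnc3c2cnn3-c2ccccc2)CC1`, in a functional assay on cells (Rhabdomyosarcoma cell, Homo sapiens) for cytotoxicity (a higher number here means a weaker inhibitor, a lower number a stronger inhibitor), gives only a limit, > 25000 nM.
Compound 2, `c1ccc(C(c2ccco2)N2CCN(c3ncnc4c3cnn4-c3ccccc3)CC2)cc1`, in this assay gives only a limit, > 25000 nM.
Compound 3, `c1ccc(C(c2ccccn2)N2CCN(c3ncnc4c3cnn4-c3ccccc3)CC2)cc1`, in this assay gives only a limit, > 25000 nM.

Compound 2 stands at the limit of this assay, and the two further values shown are limits as well, as the limit of > 25000 nM in this assay, at which 3 of the 3 values shown sit, records. The three measured steps, a step that the two limits leave unreadable from compound 1 to compound 2, a step that the two limits leave unreadable from compound 1 to compound 3 and a step that the two limits leave unreadable from compound 2 to compound 3, are all unreadable, each with both ends at the limit of > 25000 nM in this assay, at which 3 of the 3 values shown sit.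

Compound 4, `c1ccc(C(c2nccs2)N2CCN(c3ncnc4c3cnn4-c3ccccc3)CC2)cc1`, differs from compound 2 in one place: 1,3-thiazol-2-yl in place of furan-2-yl on a saturated chain carbon bound to an amine nitrogen in a ring and an aromatic carbon. All three measured steps concern a ring swap at this same place, and none yields a readable size, so they give no direction and no size to expect in this assay beyond what the limit allows. Compound 4 is therefore expected to remain at the limit, with an estimated 30000 nM and a range from 15000 nM to 80000 nM. The estimated step that the limit leaves unreadable from compound 2 to compound 4 amounts to none beyond the scatter.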

Compound 4, half-maximal inhibitory concentration: > 25000 nM
Compound 4: no number, only a limit; the forecaster's own chance of this, stated with the estimate: 85%; the middle value lies beyond the limit too.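

Compound 4 gives only a limit in this assay, > 25000 nM, so its steps from compound 1, compound 2 and compound 3 cannot be read: the limit of > 25000 nM in this assay, at which 4 of the 4 values shown sit.

The compounds shown leave open whether any group at this place on the shared core gives a readable value in this assay.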